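Chloro for Methyl on the Pendant Phenyl Ring

This account rests on a few compounds, and the source may have more. Where it says the series, first, only, none or still open, it means among the compounds named here.

Two members of this series have been measured in a functional assay on CCRF-CEM cells (Homo sapiens) for inhibition, read by cell counting, with a stated time of 3 days; on this read-out higher numbers stand for weaker inhibition and lower numbers for stronger inhibition. Compound 1 `Nc1cccc(-c2cn3nc(-c4cccs4)sc3n2)c1` gives only a limit, > 250000 nM, in this assay. Compound 2 `Cc1ccc(-c2nn3cc(-c4cccc(N)c4)nc3s2)cc1` carries 4-methylphenyl where compound 1 carries thiophen-2-yl. In this assay compound 2 gives 5900 nM, the only real number shown. The other value, that of compound 1, is the limit noted as the limit of > 250000 nM in this assay, at which 1 of the 2 values shown sits. That swap produced an at least 42-fold lower number from compound 1 to compound 2 (1.62 log units; beyond the scatter). Compound 3 `Nc1cccc(-c2cn3nc(-c4ccc(Cl)cc4)sc3n2)c1` differs from compound 2 by chloro in place of methyl on an aromatic carbon. Within the data shown here, no measured step touches this position: the one step on record exchanges the whole pendant ring rather than a single substituent on it, so it offers no direct guide to the size or direction of a methyl-to-chloro change. On that basis the expected step is a 1.2-fold lower number from compound 2 to compound 3 (0.07 log units; within the scatter), not beyond the scatter. Compound 3 is therefore estimated at 5000 nM, with a range from 1500 nM to 20000 nM in this assay.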

Compound 3, half-maximal inhibitory concentration: > 250000 nM
Compound 3: no number, only a limit (the forecaster's own chance of this, stated with the estimate: 10%); middle value at least 50-fold (1.69 log units) away from the limit.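

Among these compounds, the exchange of a single heavy atom on the six-membered aromatic ring, which no earlier step isolated, is far from neutral in this assay: chloro in place of methyl gives an at least 42-fold higher number from compound 2 to compound 3 (1.62 log units; beyond the scatter). The earlier step therefore cannot be credited to a phenyl ring alone, as 4-chlorophenyl does not keep the activity and, of the three compounds, only compound 2, with 4-methylphenyl, gives a real number. Compound 3 gives only a limit, as does compound 1, so the step between these two cannot be read: the limit of > 250000 nM in this assay, at which 2 of the 3 values shown sit.

As far as these compounds go, whether other groups at this place, such as methoxy, ethyl or an amine, or the plain phenyl ring would keep a measurable number remains open. Also open, from the compounds shown here alone, is how far past its limit compound 3 actually lies.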